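Replacing the trimethoxyphenyl with an isopropylphenyl

The compounds below may be only part of what the source reports. "The series", "measured", "known", "first", "only" and "open" are said of these compounds alone.

In a functional assay on P338 cells (Mus musculus) for antiproliferative activity (on this read-out lower numbers stand for stronger inhibition and higher numbers for weaker inhibition), compound 2 `COc1cc(/C=C/C(=O)c2ccc(OCCn3cc(CN4C(=O)/C=C/C(C)(C)C/C=C(\C)CC/C=C/4C)nn3)cc2O)cc(OC)c1OC` gives 0.89 ug/mL, and compound 1 `COc1cccc(/C=C/C(=O)c2ccc(OCCn3cc(CN4C(=O)/C=C/C(C)(C)C/C=C(\C)CC/C=C/4C)nn3)cc2O)c1` gives 0.89 ug/mL. The step of no change at the digits printed from compound 1 to compound 2 (within the scatter) shows that changing the methoxy pattern on this aryl ring left the read-out where it was. Compound 3 `C/C1=C\CC(C)(C)/C=C/C(=O)N(Cc2cn(CCOc3ccc(C(=O)/C=C/c4ccc(C(C)C)cc4)c(O)c3)nn2)/C(C)=C/CC1` alters the same position differently: 4-isopropylphenyl in place of 3,4,5-trimethoxyphenyl on a double-bonded chain carbon bound to a double-bonded chain carbon. For the measured compounds named here, no measured step removes every methoxy group, so that flat step is the only guide. Compound 3 is therefore expected to remain near compound 2, with an expected step of a 1.3-fold higher number from compound 2 to compound 3 (0.13 log units; within the scatter). Compound 3 is estimated at 1.2 ug/mL, with a range from 0.5 ug/mL to 3 ug/mL.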

Compound 3, half-maximal inhibitory concentration: 1.39 ug/mL
The estimate for compound 3 lay 1.2-fold (0.06 log units) below the measured number; low and high end bracket the measured number.
By their numbers in this assay, from the lowest: compounds 1, 2 and 3 (each within the scatter of the next).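

In this assay the read-out shows a 1.6-fold higher number from compound 2 to compound 3 (0.19 log units; within the scatter) and a 1.6-fold higher number from compound 1 to compound 3 (0.19 log units; within the scatter) when 4-isopropylphenyl, with no oxygen and no hydrogen-bond acceptors, enters at this position. For the compounds shown here, the methoxy groups of the earlier compounds are therefore not required to keep the read-out within the scatter here, so this position has now accepted an aryl ring carrying only carbon substituents. Nothing available explains this tolerance.

The compounds shown leave open whether a ring bearing an amine or a carboxylic acid would stay level with these three. They also leave open whether an unsubstituted phenyl would do so.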